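This account rests on a few compounds, and the source may have more. Where it says the series, first, only, none or still open, it means among the compounds named here.

Measured compounds:
compound 1, `ClCc1cccc(Cn2cnc3ncnc(Cl)c32)c1`, gives 5750 nM
compound 2, `ClCc1ccc(Cn2cnc3nc(Cl)nc(Cl)c32)cc1`, gives 1120 nM
compound 3, `ClCc1cccc(Cn2cnc3nc(Cl)nc(Cl)c32)c1`, gives 1770 nM

All three were tested in a functional assay on SK-MEL-2 cells (Homo sapiens) for cytotoxicity, read by sulforhodamine B assay, with a stated time of 48 h; a lower number here means a stronger inhibitor of growth, a higher number a weaker inhibitor of growth. Compound 2 and compound 3 are built from the same atoms joined differently; the difference between the two cores is not broken down here, and their two values lie within the usual scatter of each other, so nothing can be read into the gap between them.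

Compound 3 and compound 1 differ in one place. The change is hydrogen in place of chloro on an aromatic carbon and it made a step of a 3.2-fold higher number from compound 3 to compound 1 (0.51 log units; beyond the scatter), a modest move toward weaker growth inhibition.

Compound 4, `ClCc1ccc(Cn2cnc3ncnc(Cl)c32)cc1`, has not yet been measured. Among the compounds with values here, it is related to compound 2 by hydrogen in place of chloro on an aromatic carbon, which is the same change as the one from compound 3 to compound 1: the same group leaves, the same atom enters, and the surroundings of the place are described in the same words. Within the data shown here, the one pair of measured compounds that shows this change is therefore the only basis for an expectation, and with a single example the confidence is limited.

On that basis, compound 4 is expected to show a step of a 3.2-fold higher number from compound 2 to compound 4 (0.51 log units; beyond the scatter) in this assay, matching the direction and roughly the size of a 3.2-fold higher number from compound 3 to compound 1 (0.51 log units; beyond the scatter). The estimated value for compound 4 is 3600 nM, with a range from 1800 nM to 7500 nM.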

Compound 4, concentration for 50% growth inhibition: 6300 nM
For compound 4 the middle estimate is 1.8-fold (0.24 log units) below the measured one; measured number inside the range.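

In this assay, putting hydrogen in place of the chloro group on the aromatic carbon between two ring nitrogen atoms gave a 5.6-fold higher number from compound 2 to compound 4 (0.75 log units; beyond the scatter), a move toward weaker growth inhibition. This is the same direction as in the earlier pair, and the two steps do not differ by more than the scatter allows: the same change on two cores in this assay, a 3.2-fold higher number (0.51 log units; beyond the scatter) from compound 3 to compound 1 and a 5.6-fold higher number (0.75 log units; beyond the scatter) from compound 2 to compound 4, 1.7-fold (0.24 log units) apart, within the scatter of two such steps. So in these two pairs the change carried from one core to the other in direction and in rough size, but two pairs are a small sample, and they show neither why losing the chloro group weakens growth inhibition nor whether the same step would appear on a core outside these four compounds.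

The compounds shown leave open what an amine or a methoxy group would do on that same carbon in place of chloro, since hydrogen is the only replacement seen here. Also open, as far as these compounds go, is what would happen if the chloromethyl group carried by all four compounds gave way to a plain methyl or a hydroxymethyl group.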